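The source may report more compounds than this note shows. Statements on the series, on what has been measured and on what is new or still open speak of the compounds shown alone.

Compound 3 `C=C1C(=O)O[C@H]2[C@H]1[C@@H](OC(=O)/C(C)=C/C)C[C@@](C)(O)[C@]13C=C[C@](C)([C@H]21)[C@]1(C3)C(=O)O[C@@H]2[C@H]3C(C)=CC[C@H]3[C@](C)(O)C[C@H](OC(=O)/C(C)=C/C)[C@H]21` is the only one of the three measured compounds that returns a number in a functional assay on SUNE1 cells (Homo sapiens) for cytotoxicity, read by MTT assay, with a stated time of 48 h (on this read-out higher numbers stand for weaker inhibition and lower numbers for stronger inhibition), where compound 3 gives 4300 nM. Compound 1 `C=C1C(=O)O[C@@H]2[C@@H]3[C@@]4(C=C[C@@]3(C)[C@]3(C4)C(=O)O[C@@H]4[C@H]5C(C)=CC[C@H]5[C@](C)(O)C[C@H](O)[C@H]43)[C@](C)(O)CC[C@@H]12` reaches only a limit of this assay, giving > 10000 nM. Compound 2 `C=C1C(=O)O[C@H]2[C@H]1[C@@H](OC(=O)/C(C)=C/C)C[C@@](C)(O)[C@]13C=C[C@](C)([C@H]21)[C@]1(C3)C(=O)O[C@@H]2[C@H]3C(C)=CC[C@H]3[C@](C)(O)C[C@H](O)[C@H]21` likewise stops at a limit, giving > 10000 nM. Between them, a step that the two limits leave unreadable from compound 1 to compound 2; the following step, an at least 2.3-fold lower number from compound 2 to compound 3 (0.36 log units; beyond the scatter), is the single readable one. Compound 4 `C=C1C(=O)O[C@@H]2[C@@H]3[C@@]4(C=C[C@@]3(C)[C@]3(C4)C(=O)O[C@@H]4[C@H]5C(C)=CC[C@H]5[C@](C)(O)C[C@H](OC(=O)/C(C)=C/C)[C@H]43)[C@](C)(O)CC[C@@H]12` differs from compound 3 by the change (hydrogen in place of ((1-methylprop-1-en-1-yl)carbonyl)oxy on a saturated ring carbon). Within the data shown here, the one measured step at that same position, from compound 1 to compound 2, has no readable size, and the readable step concerns the oxygen on a saturated carbon instead. Compound 4 keeps only the ester that compound 3 gained at the step of an at least 2.3-fold lower number from compound 2 to compound 3 (0.36 log units; beyond the scatter), so a weaker result than compound 3 is expected, with a real chance that only a limit is reported. In this assay compound 4 is estimated at 9000 nM, within 3500 nM to 25000 nM, the expected step being a 2.1-fold higher number from compound 3 to compound 4 (0.32 log units; beyond the scatter).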

Compound 4, half-maximal inhibitory concentration: > 10000 nM
Compound 4 gave a limit, no number (the forecaster's own chance of this, stated with the estimate: 45%); middle value at least 1.1-fold (0.04 log units) from the limit.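

In this assay, replacing the ((1-methylprop-1-en-1-yl)carbonyl)oxy on the saturated ring carbon of the seven-membered ring with hydrogen gives the first readable size for a change at this position, an at least 2.3-fold higher number from compound 3 to compound 4 (0.36 log units; beyond the scatter). Among these compounds, compound 3, which carries this group and the (1-methylprop-1-en-1-yl)carbonyl on the other oxygen, is the only one of the four compounds to return a number, and removing either one leads back to a limit. The steps from compound 1 to compound 2 and from compound 1 to compound 4 cannot be read, because both ends of each are limits: the limit of > 10000 nM in this assay, at which 3 of the 4 values shown sit.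

On these data alone, whether either ester alone contributes more than the other remains open. So does whether an acetyl ester, a longer acyl chain or an amine on this saturated ring carbon would return a number.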